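Hydroxymethyl Fluorophenyl Replaces Tert-Butylphenyl on the Core

The source may hold more compounds than are shown below. What is called first, only, known or untested is meant among the compounds shown, and "the series" means these compounds.

Compound 1 `O=C(Nc1ccc(C(F)(F)F)cc1)c1cc(=O)[nH]c2cc(Br)ccc12` and compound 2 `CC(C)(C)c1ccc(-c2ccc3c(C(=O)Nc4cccc(F)c4)cc(=O)[nH]c3c2)cc1` share an amide-bearing core and were both tested in a functional assay on KYSE-70 cells for antiproliferative activity against KYSE-70 cell line (Homo sapiens), read by MTT assay, with a stated time of 72 h; a higher number here means a weaker inhibitor, a lower number a stronger inhibitor. In this assay compound 1 gives > 20000 nM, a limit of the assay rather than a number. In this assay compound 2 likewise gives > 20000 nM, again only a limit. Compound 2 thus stands at the limit of > 20000 nM in this assay, at which 2 of the 2 values shown sit. Compound 3 `O=C(Nc1cccc(F)c1)c1cc(=O)[nH]c2cc(-c3ccc(F)c(CO)c3)ccc12` differs from compound 2 in one place: 4-fluoro-3-(hydroxymethyl)phenyl in place of 4-(tert-butyl)phenyl on an aromatic carbon. Among the compounds with values here, no measured pair shows this change, so no measured step guides it. For compound 3 the expected step that the limit leaves unreadable from compound 2 to compound 3 is none beyond the scatter. Compound 3 is expected to give 25000 nM in this assay, within 5000 nM to 100000 nM.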

Compound 3, half-maximal inhibitory concentration: > 20000 nM
Compound 3 gave a limit, no number; the forecaster's own chance of this, stated with the estimate: 70%; the middle value is on the limit's open side.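

In this assay compound 3 gives > 20000 nM, again a limit and not a number. Compound 2 also sits at a limit, so no step can be read between compound 2 and compound 3. The compounds shown leave open what change on the shared core would give a measurable value: the limit of > 20000 nM in this assay, at which 3 of the 3 values shown sit.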